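The source may hold more compounds than are shown below. What is called first, only, known or untested is meant among the compounds shown, and "the series" means these compounds.

Measured in a functional assay on A549 cells (Homo sapiens) for antiproliferative activity, read by MTT assay, with a stated time of 48 h; on this read-out lower numbers stand for stronger inhibition and higher numbers for weaker inhibition:
- compound 1 `COc1cc(-c2cccc3nc(-c4ccc(Cl)cc4)oc23)cc(OC)c1OC`: 5600 nM
- compound 2 `COc1ccc(-c2nc3c(-c4cc(OC)c(OC)c(OC)c4)cccc3o2)cc1OC`: 20100 nM

Compound 2 holds the higher of the two numbers at 20100 nM, which makes it the weaker inhibitor here. Among the measured compounds shown here, its only neighbour, compound 1, gives 5600 nM, and that gap lies beyond the scatter.

Compound 3 `COc1cc(OC)cc(-c2nc3c(-c4cc(OC)c(OC)c(OC)c4)cccc3o2)c1` has not yet been measured. It has the same atoms as compound 2, joined differently: 3,5-dimethoxyphenyl in place of 3,4-dimethoxyphenyl on an aromatic carbon. The new group sits on an aromatic carbon of a five-membered aromatic ring with 1 nitrogen and 1 oxygen, the same place that holds the old group in compound 2.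

For the measured compounds named here, no measured pair shows what such a change does, so the expectation rests on compound 2 alone, at 20100 nM. In this assay only a small shift toward lower numbers is expected, and none beyond the scatter. The expected change is a 1.3-fold lower number from compound 2 to compound 3 (0.10 log units; within the scatter). Compound 3 is estimated at 16000 nM, with an expected range from 7000 nM to 40000 nM.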

Compound 3, half-maximal inhibitory concentration: 16300 nM
Compound 3: the middle estimate sits 1.0-fold (0.01 log units) below what was measured; the measured number falls inside the stated range.
By their numbers in this assay, from the lowest: compound 1; then compounds 3 and 2 (each within the scatter of the next).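

In this assay, exchanging 3,4-dimethoxyphenyl for 3,5-dimethoxyphenyl on the aromatic carbon next to the ring nitrogen and next to the ring oxygen gives a 1.2-fold lower number from compound 2 to compound 3 (0.09 log units; within the scatter). Among the compounds shown here, this pair is the first direct reading at this place in which the group keeps the same atoms and only their arrangement differs, and the two arrangements cannot be told apart in this read-out. Nothing available explains why the two compounds read alike.

The compounds shown leave open whether a phenyl ring at this place that carries an amine or a carboxylic acid instead of the two methoxy groups would give a number clearly different from those of compound 2 and compound 3. As far as these compounds go, they also rest this reading on a single pair, so it remains open whether the same exchange would stay within the scatter if the rest of the molecule were changed as well.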